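From 2-chlorophenyl to thiophen-2-yl: what compound 3 may show

The source may hold more compounds than are shown below. What is called first, only, known or untested is meant among the compounds shown, and "the series" means these compounds.

In an ADME assay on S9 fraction from liver (Rattus norvegicus) for metabolic stability, read by LC-MS, using NADPH, with a stated time of 30 min (a lower number here means that less of the compound is left, a higher number that more of the compound is left), compound 1 (`CCCCCCCCc1ccc(OCC(=O)Cn2nnc(-c3ccccc3Cl)n2)cc1`) stands lowest of the two measured compounds (28%), while compound 2 (`CCCCCCCCc1ccc(OCC(=O)Cn2nnc(-c3ccc(S(=O)(=O)N(C)C)cc3)n2)cc1`) lies higher (65%). Compound 3 (`CCCCCCCCc1ccc(OCC(=O)Cn2nnc(-c3cccs3)n2)cc1`) carries thiophen-2-yl in place of 2-chlorophenyl on an aromatic carbon. Among the compounds with values here, the one measured step at this place (a number 37 percentage points higher from compound 1 to compound 2 (beyond the scatter)) was large and beyond the scatter, but it brought in 4-(dimethylsulfamoyl)phenyl, a very different group, so it offers only weak guidance. A small upward move within the scatter is therefore expected (a number 6 percentage points higher from compound 1 to compound 3 (within the scatter)). The expected value for compound 3 is (34%), with an estimated range (15% to 56%).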

Compound 3, percent of the compound remaining: 8%
The estimate for compound 3 lay 26 percentage points above the measured number, outside the stated range (below it).
By their numbers in this assay, from the lowest: compound 3; then compound 1; then compound 2.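

In this assay, the step of a number 20 percentage points lower from compound 1 to compound 3 (beyond the scatter) shows that this aromatic carbon can also drive the number down, not only up, when a smaller ring enters. Together with the step of a number 57 percentage points lower from compound 2 to compound 3 (beyond the scatter), it places thiophen-2-yl lowest of the three groups shown and widens the span seen at this position. No measurement shown here explains the fall. It remains open whether another five-membered aromatic ring, such as furan-2-yl, would give a similarly low number, and where an unsubstituted phenyl would fall among these groups.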